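Replacing an aryl amine with an eight-membered ring amine

A few compounds are considered here, and "the series" means these few. Any claim that something is new, unique, unknown or untested is made for them only; others in the source may bear on it.

Measured so far:
Compound 1 `CC(C(=O)NCc1ccc(C(F)(F)F)nc1NCc1ccc(Cl)cc1)c1ccc(NS(C)(=O)=O)c(F)c1`: 414 nM
Compound 2 `CC(C(=O)NCc1ccc(C(F)(F)F)nc1N(C)c1ccccc1)c1ccc(NS(C)(=O)=O)c(F)c1`: 57.4 nM
Compound 3 `CC(C(=O)NCc1ccc(C(F)(F)F)nc1N1CCC(C(=O)c2ccc(F)cc2)CC1)c1ccc(NS(C)(=O)=O)c(F)c1`: 990 nM

All three values come from a functional assay on CHO-K1 cells for antagonist activity at transient receptor potential cation channel subfamily V member 1 (Homo sapiens), read by FLIPR; a lower number here means a stronger inhibitor, a higher number a weaker inhibitor. Compound 2 stands lowest of the three; compound 1 sits at a 7.2-fold lower number from compound 1 to compound 2 (0.86 log units; beyond the scatter) from it, and compound 3 shows a higher number still. Compound 4 `CC(C(=O)NCc1ccc(C(F)(F)F)nc1N1CCCCCCC1)c1ccc(NS(C)(=O)=O)c(F)c1` is not yet measured. It differs from compound 2 by a group of 8 heavy atoms (7 carbon, 1 nitrogen; one eight-membered non-aromatic ring with 1 hetero atom) in place of a group of 8 heavy atoms (7 carbon, 1 nitrogen; one six-membered aromatic ring of carbon only), on an aromatic carbon. For the measured compounds named here, only one measured step bears on this position: a 7.2-fold lower number from compound 1 to compound 2 (0.86 log units; beyond the scatter), which favoured the methyl(phenyl)amino group. Compound 3, which also carries a saturated ring amine at this place, gives a higher number than compound 2. For compound 4 a step upward beyond the scatter is therefore expected, a 6.1-fold higher number from compound 2 to compound 4 (0.79 log units; beyond the scatter), giving an estimated 350 nM with a range from 90 nM to 1400 nM.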

Compound 4, half-maximal inhibitory concentration: 27.8 nM
The estimate for compound 4 lay 13-fold (1.10 log units) above the measured number; the measured number lies below the stated range.
By their numbers in this assay, from the lowest: compound 4; then compound 2; then compound 1; then compound 3.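

At this place, an aromatic ring in the group is not needed for activity in this assay: the eight-membered ring amine gives a 2.1-fold lower number from compound 2 to compound 4 (0.31 log units; beyond the scatter). Measured against the (4-chlorobenzyl)amino group, the same ring gives a 15-fold lower number from compound 1 to compound 4 (1.17 log units; beyond the scatter). A saturated ring amine alone does not guarantee this, since compound 3 gives 990 nM while compound 4 gives 27.8 nM.

From the compounds shown here alone, whether a plain pyrrolidine, piperidine or morpholine would match the eight-membered ring remains open. Nothing measured here explains these differences.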